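Compound 4: a new group on the amide nitrogen

A few compounds are considered here, and "the series" means these few. Any claim that something is new, unique, unknown or untested is made for them only; others in the source may bear on it.

Values measured so far in an ADME assay on HEp-2 cells (Homo sapiens) for cytotoxicity (on this read-out higher numbers stand for lower toxicity in this test and lower numbers for higher toxicity in this test), are these
- compound 1 `Cc1cccc(NC(=O)[C@@H]2CCCN2S(=O)(=O)c2cccc3cccnc23)c1` gives 25500 nM as a number
- compound 2 `CCc1ccccc1NC(=O)[C@@H]1CCCN1S(=O)(=O)c1cccc2cccnc12` gives > 50000 nM as a limit of the assay, not a number
- compound 3 `CC(C)c1ccccc1NC(=O)[C@@H]1CCCN1S(=O)(=O)c1cccc2cccnc12` gives 29900 nM as a number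

Compound 3 stands level with compound 1: the step is a 1.2-fold higher number from compound 1 to compound 3 (0.07 log units; within the scatter) and so gives no order between them. Its other neighbour offers only a bound, an at least 1.6-fold lower number from compound 2 to compound 3 (0.22 log units; that floor lies within the scatter), because compound 2 has a limit and no number.

In compound 4 `Cc1cc(C)cc(NC(=O)[C@@H]2CCCN2S(=O)(=O)c2cccc3cccnc23)c1`, 3,5-dimethylphenyl comes in place of 2-isopropylphenyl on an amide-type nitrogen 3,5-dimethylphenyl in place of 2-isopropylphenyl on an amide-type nitrogen and the rest stays the same. Another measured swap on that nitrogen is an at least 1.9-fold higher number from compound 1 to compound 2 (0.29 log units; that floor lies within the scatter). The swap from compound 1 to compound 3 has already been given, and neither of the two is shown beyond the scatter. No change beyond the scatter is therefore expected in this assay here. The expected size is a 1.0-fold higher number from compound 3 to compound 4 (0.00 log units; within the scatter) by this estimate. For compound 4 the estimate is 30000 nM, with an expected range from 16000 nM to 55000 nM in this test.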

Compound 4, half-maximal cytotoxic concentration: 31300 nM
Estimate against measurement, compound 4: 1.0-fold (0.02 log units) below, within the range that was stated.
By their numbers in this assay, from the lowest: compounds 1, 3 and 4 (each within the scatter of the next). At a limit, above all of these: compound 2.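

In this assay, methyl in place of hydrogen on an aromatic carbon of the compound 1 ring stays within the scatter: a 1.2-fold higher number from compound 1 to compound 4 (0.09 log units; within the scatter). Moving to 3,5-dimethylphenyl from 2-isopropylphenyl on the amide-type nitrogen also stays within the scatter, at a 1.0-fold higher number from compound 3 to compound 4 (0.02 log units; within the scatter), so compounds 1, 3 and 4 give no order among themselves. Only a bound comes from an at least 1.5-fold lower number from compound 2 to compound 4 (0.20 log units; that floor lies within the scatter), because the first of these two compounds sits at a limit of the assay, not a number: the limit of > 50000 nM in this assay, at which 1 of the 4 values shown sits.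

All the groups shown on this nitrogen are phenyl rings carrying only methyl, ethyl or isopropyl. As far as these compounds go, whether a phenyl ring bearing a carboxylic acid or an amine, or a saturated chain in place of the ring, would move this assay beyond the scatter remains open.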